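A butyl chain in place of methyl on a shared core

The compounds below may be only part of what the source reports. "The series", "measured", "known", "first", "only" and "open" are said of these compounds alone.

The study compares compound 2 `COc1cc(C)ccc1COc1ccc2c(c1)CCC(CN1CC(C(=O)O)C1)=C2C` with compound 1 `CC1=C(CN2CC(C(=O)O)C2)CCc2cc(OCC3CCc4ccccc4C3)ccc21`, which shares the core but carries a different ether side. In a functional assay on the whole organism (strain BALB/c) with Mus musculus as the target, with a stated time of 4 h (on this read-out higher numbers stand for an effect only at larger amounts of compound and lower numbers for an effect already at smaller amounts), compound 1 gives "not determined" (no result reported). In this assay compound 2 gives only a limit, > 0.1 mg/kg, not a single number (the limit of > 0.1 mg/kg in this assay, at which 1 of the 2 values shown sits). Compound 3 `CCCCc1ccc(COc2ccc3c(c2)CCC(CN2CC(C(=O)O)C2)=C3C)c(OC)c1` differs from compound 2 by propyl in place of hydrogen on a saturated chain carbon bound to an aromatic carbon. Among the measured compounds shown here, no measured step is available, so a step within the scatter is expected, a step that the limit leaves unreadable from compound 2 to compound 3. Compound 3 is expected at about 0.3 mg/kg, between 0.05 mg/kg and 2 mg/kg, and may again be reported only as a limit.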

Compound 3, dose for half-maximal effect: 0.09 mg/kg
The estimate for compound 3 lay 3.3-fold (0.52 log units) above the measured number; the range from low to high includes it.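

In this assay compound 3 gives 0.09 mg/kg, the only single number among the compounds shown, so this saturated chain carbon bound to an aromatic carbon can carry propyl and still give a measurable dose. The change reads as an at least 1.1-fold lower number from compound 2 to compound 3 (0.04 log units; that floor lies within the scatter), which fixes only a floor and not the true size of the step. Compound 2 is held by a limit alone: the limit of > 0.1 mg/kg in this assay, at which 1 of the 3 values shown sits.

The compounds shown leave open how an ethyl chain, a longer hexyl chain or an amine would read at this place.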